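The source may hold more compounds than are shown below. What is called first, only, known or untested is meant among the compounds shown, and "the series" means these compounds.

Working notes on the series, measured so far:
- compound 1 `CCN1CCN(c2nc(C)nc3c2nc(-c2ccccc2Cl)n3CCOC)CC1`: 31%
- compound 2 `CC(=O)NCCn1c(-c2ccccc2Cl)nc2c(N3CCN(C)CC3)nc(C)nc21`: 0%
- compound 3 `Cc1nc(N2CCN(C)CC2)c2nc(-c3cccc(C(F)(F)F)c3)n(C3CCOCC3)c2n1`: 19%

These values come from an ADME assay (liver) for metabolic stability, with Liver microsome (Homo sapiens) as the target, read by LC-MS, using microsomes, with a stated time of 30 min, tested at 4 uM; on this read-out lower numbers stand for a less stable compound and higher numbers for a more stable compound. Compound 3 stands second highest of the three, below compound 1 and above compound 2, with both gaps beyond the scatter. The next compound to be measured is compound 4 `Cc1nc(N2CCN(C)CC2)c2nc(-c3ccccc3C#N)n(C3CCOCC3)c2n1`, which differs from compound 3 as follows: 2-cyanophenyl in place of 3-(trifluoromethyl)phenyl on an aromatic carbon. In words, it has 2-cyanophenyl in place of 3-(trifluoromethyl)phenyl on an aromatic carbon. Within the data shown here, no measured pair differs in one place only, so the data give no direct guide to the size of this step. The expected result is a number 6 percentage points higher from compound 3 to compound 4 (within the scatter), an estimated small rise that stays within the scatter. For compound 4 the estimated value is 25%, with an expected range of 8% to 48%.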

Compound 4, percent of the compound remaining: 20%
Compound 4: middle estimate off by 5 percentage points, on the high side; measured number inside the range.
By their numbers in this assay, from the lowest: compound 2; then compounds 3 and 4 (each within the scatter of the next); then compound 1.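

In this assay, among these compounds, putting 2-cyanophenyl in place of 3-(trifluoromethyl)phenyl on the aromatic carbon between two ring nitrogen atoms gives a number 1 percentage points higher from compound 3 to compound 4 (within the scatter) and thus the first one-place reading: the two groups are not told apart at this position. Nitrile and trifluoromethyl also differ in where they stand on the phenyl ring, so this pair cannot separate the two changes. No measurement at hand explains this result.

Open, as far as these compounds go, is whether an unsubstituted phenyl, or a phenyl carrying an amine or a carboxylic acid, would also leave the number within the scatter.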